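An Octyl Chain Gives Way to 4-Methylphenyl

A few compounds are considered here, and "the series" means these few. Any claim that something is new, unique, unknown or untested is made for them only; others in the source may bear on it.

Among the measured compounds shown here, compound 1 `CCCCCCCCNc1nc(SCc2ccc(C(F)(F)F)cc2)nc2ccccc12` was run in a functional assay on MGC-803 cells (Homo sapiens) for cytotoxicity, read by MTT assay, with a stated time of 72 h (a higher number here means a weaker inhibitor, a lower number a stronger inhibitor), where compound 1 gives 12600 nM, the highest of the two numbers so far, though its only neighbour lies within the scatter. That neighbour, compound 2 `O=[N+]([O-])c1ccc(Nc2nc(SCc3ccc(C(F)(F)F)cc3)nc3ccccc23)cc1`, gives 8170 nM in this assay, the step being a 1.5-fold lower number from compound 1 to compound 2 (0.19 log units; within the scatter). Compound 3 `Cc1ccc(Nc2nc(SCc3ccc(C(F)(F)F)cc3)nc3ccccc23)cc1` differs from compound 1 by 4-methylphenyl in place of octyl on a nitrogen on an aromatic ring. For the measured compounds named here, the one step bearing on this change, a 1.5-fold lower number from compound 1 to compound 2 (0.19 log units; within the scatter), stayed within the scatter, so for compound 3 no step beyond the scatter is expected in this assay, the estimated step being a 1.3-fold lower number from compound 1 to compound 3 (0.10 log units; within the scatter). Compound 3 is therefore expected at about 10000 nM, between 4000 nM and 25000 nM.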

Compound 3, half-maximal inhibitory concentration: 36100 nM
For compound 3 the middle estimate is 3.6-fold (0.56 log units) below the measured one; measured number outside the range, above it.
By their numbers in this assay, from the lowest: compounds 2 and 1 (each within the scatter of the next); then compound 3.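

Compound 3 shows that an aromatic group on this nitrogen does not by itself leave the number unchanged: in this assay there is a 2.9-fold higher number from compound 1 to compound 3 (0.46 log units; beyond the scatter), a step beyond the scatter, unlike the earlier step from octyl to 4-nitrophenyl. The group carried on that aromatic ring also matters, with methyl in place of nitro giving a 4.4-fold higher number from compound 2 to compound 3 (0.65 log units; beyond the scatter). No measurement shown here accounts for this difference.

The compounds shown leave open how an unsubstituted phenyl, or an amine or carboxylic acid in place of the methyl, would compare. They also leave open how a shorter chain such as butyl would compare with octyl on this nitrogen.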